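The source may hold more compounds than are shown below. What is called first, only, known or untested is meant among the compounds shown, and "the series" means these compounds.

Three ureas on a shared core have been run in an ADME assay on the whole organism with Oryza sativa as the target, tested at 10 uM; a higher number here means a weaker effect of the compound at the concentration tested, a lower number a stronger effect. Compound 1 `Cc1ccc(NC(=O)N[C@H](C)c2ccccc2)cc1` gives 64%. Compound 2 `Cc1ccc(NC(=O)N[C@@H](C)c2ccccc2)cc1` gives 100%, and compound 3 `CC(C)c1ccccc1NC(=O)N[C@@H](C)c1ccccc1` gives 93%. Going by the values given here, the only single-point step measured is a number 36 percentage points higher from compound 1 to compound 2 (beyond the scatter); the two compounds are the same in atoms and bonds, and the step rests on (the fact that compounds 1 and 2 differ only in the configuration as drawn). Compound 2 stands at the upper end of the three numbers; compound 3 lies within the scatter of it, and compound 1 lies beyond the scatter below it.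

Compound 4 `CCCCCCCc1ccc(NC(=O)N[C@@H](C)c2ccccc2)cc1` has not yet been measured in this assay. It differs from compound 2 by hexyl in place of hydrogen on a saturated chain carbon bound to an aromatic carbon. Among the compounds with values here, no measured step touches this change: the step from compound 1 to compound 2 is a change of configuration only, and compound 3 is not joined to compound 2 by a single counted step. The expectation for compound 4 in this assay therefore rests on compound 2 alone, with 100% as the anchor, and on the absence of any measured step for a lengthened chain on the core. Compound 4 is expected to give about 90%, within 65% to 100%. The expected step is a number 10 percentage points lower from compound 2 to compound 4 (within the scatter), meaning no step beyond the scatter is expected, with the range opened downward because compound 2 sits at the top of the three numbers with 100%.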

Compound 4, a percentage reported as activity, at one concentration (the size of the read-out at that concentration, not a potency): 99%
For compound 4 the middle estimate is 9 percentage points below the measured one; the measured number falls inside the stated range.
By their numbers in this assay, from the lowest: compound 1; then compounds 3, 4 and 2 (each within the scatter of the next).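

Working notes on the series: in this assay, hexyl in place of hydrogen on a saturated chain carbon bound to an aromatic carbon gives a number 1 percentage points lower from compound 2 to compound 4 (within the scatter), the first measured step at this place on the shared core. Read the other way, methyl to heptyl in the configuration drawn for compound 2 leaves no step beyond the scatter, so this place accepts that longer chain without a measurable change in this read-out, while the one step beyond the scatter remains the change of configuration, a number 36 percentage points higher from compound 1 to compound 2 (beyond the scatter). Nothing on hand bears on why the chain change leaves the number within the scatter.

Open, from the compounds shown here alone, is whether the same chain change would also leave the number within the scatter in the configuration drawn for compound 1, which gives 64% in this assay and so has more room for a change to show in either direction. Also open, going by these compounds, is what a carboxylic acid, an amine or a ring-bearing chain would do at this same place on the core of compound 2.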